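Ethyl on the Benzimidazole Core of Compound 1

The compounds below may be only part of what the source reports. "The series", "measured", "known", "first", "only" and "open" are said of these compounds alone.

Measured compounds:
compound 1 `CS(=O)(=O)N1CCN(CC(O)CN2CCC(CNC(=O)c3cccc4[nH]cnc34)CC2)CC1` — 10 nM
compound 2 `CS(=O)(=O)N1CCN(CC(O)CN2CCC(NC(=O)c3cccc4[nH]cnc34)CC2)CC1` — 631 nM

The study centres on a functional assay for agonist activity at 5-hydroxytryptamine receptor 4 (Homo sapiens), read by cAMP accumulation; on this read-out lower numbers stand for an effect already at smaller amounts and higher numbers for an effect only at larger amounts of compound. Compound 1 stands at the lowest of the two numbers shown, and compound 2 sits at a far higher value; the gap is wide, so the two are clearly apart on this read-out.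

The question is what happens when compound 1 is carried to compound 3 `CCc1nc2c(C(=O)NCC3CCN(CC(O)CN4CCN(S(C)(=O)=O)CC4)CC3)cccc2[nH]1`. The change is ethyl in place of hydrogen on an aromatic carbon, on the core shared by both compounds, on an aromatic carbon of a five-membered aromatic ring with two nitrogen, part of a fused system of two rings.

Among the compounds with values here, no comparable step has been measured here, so the size can only be guessed. Compound 3 is expected to land close to compound 1, with a step of a 1.7-fold lower number from compound 1 to compound 3 (0.22 log units; within the scatter) of about the scatter, if anything toward a lower number. Compound 3 is thus estimated at 6 nM, within 1.5 nM to 25 nM.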

Compound 3, half-maximal effective concentration: 1 nM
Estimate against measurement, compound 3: 6.0-fold (0.78 log units) above, outside the stated range (below it).
By their numbers in this assay, from the lowest: compound 3; then compound 1; then compound 2.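

In this assay, ethyl in place of hydrogen on the aromatic carbon between two ring nitrogen atoms gives a 10-fold lower number from compound 1 to compound 3 (1.00 log units; beyond the scatter), so this carbon of the shared core accepts a small alkyl chain and the number moves lower, beyond the scatter. Compound 1 and compound 2 both carry hydrogen there, so their values said nothing about this carbon. Nothing measured here accounts for the step.

As far as these compounds go, the account rests on this single step, so it remains open whether methyl, a longer chain such as propyl, or an amine on the same carbon would move the number in the same direction or by a similar amount. From the compounds shown here alone, whether ethyl at this carbon would give a similar step on compound 2 also remains open.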